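The compounds below may be only part of what the source reports. "The series", "measured", "known", "first", "only" and "open" are said of these compounds alone.

Values in a functional assay on AGS cells (Homo sapiens) for inhibition, read by MTT assay, with a stated time of 72 h; on this read-out lower numbers stand for stronger inhibition and higher numbers for weaker inhibition:

- Compound 1 `Cc1ccc(N2CCCC2)c(C(=O)Nc2ccc(CNC(=O)OCc3cccnc3)cc2)c1`: 24700 nM
- Compound 2 `O=C(NCc1ccc(NC(=O)c2cccc(F)c2N2CCCC2)cc1)OCc1cccnc1`: > 100000 nM (a limit)
- Compound 3 `O=C(NCc1ccc(NC(=O)c2ccc(F)cc2N2CCCC2)cc1)OCc1cccnc1`: > 100000 nM (a limit)

Compound 2 has no exact number on this read-out. Compound 2 gives > 100000 nM, which is a limit of the assay and not a number. Compound 3 gives > 100000 nM, which is also a limit. Of the measured set, these two fluoro compounds make up (the limit of > 100000 nM in this assay, at which 2 of the 3 values shown sit).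

Compound 4 `Cc1cccc(C(=O)Nc2ccc(CNC(=O)OCc3cccnc3)cc2)c1N1CCCC1` is not yet measured. It comes from compound 2 by one small swap: methyl in place of fluoro on an aromatic carbon.

Among the measured compounds shown here, no measured pair shows this swap directly, so the expectation rests on very little. For the measured compounds named here, the one measured compound with a methyl group is compound 1, which gives 24700 nM, a true number in this assay. That value suggests a modest move towards stronger inhibition, though compound 4 may well stay at the limit. The expected size of the change is an at least 2.2-fold lower number from compound 2 to compound 4 (0.34 log units; beyond the scatter), and it can only be a rough estimate. For compound 4 the estimated value is 45000 nM. The expected range for compound 4 runs from 15000 nM to 100000 nM.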

Compound 4, half-maximal inhibitory concentration: > 100000 nM
Compound 4: only a limit was reported (the forecaster's own chance of this, stated with the estimate: 35%); middle value at least 2.2-fold (0.34 log units) from the limit.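

Compound 2 and compound 4 both stop at a limit of the assay, not at a true number, so the step between these two compounds cannot be read: the limit of > 100000 nM in this assay, at which 3 of the 4 values shown sit.

The compounds shown leave open whether methyl in place of fluoro on an aromatic carbon changes inhibition at all.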